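A few compounds are considered here, and "the series" means these few. Any claim that something is new, unique, unknown or untested is made for them only; others in the source may bear on it.

Notes on the series. For the measured compounds named here, compound 3 `CCCCN(CC)c1cc(C)nc2c1NC(=O)CN2c1ccc(Cl)cc1Cl` gives 0.49 nM in an assay on isolated protein for binding affinity to corticotropin-releasing factor receptor 1 (Rattus norvegicus) (on this read-out lower numbers stand for stronger inhibition and higher numbers for weaker inhibition), the lowest of the three numbers so far. Compound 2 `CCCCN(CC)c1cc(C)nc2c1NC(=O)CN2c1ccc(OC)cc1C` gives 0.92 nM, and the step of a 1.9-fold lower number from compound 2 to compound 3 (0.27 log units; within the scatter) is within the scatter. Compound 1 `CCCN(CCC)c1cc(C)nc2c1NC(=O)CN2c1ccc(C#N)cc1Cl` gives 1.2 nM, a gap from compound 3 that is beyond the scatter; compound 1 and compound 3 differ in two places, so only their two values can be compared.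

Compound 4 `CCCCN(CC)c1cc(C)nc2c1NC(=O)CN2c1ccc(C#N)cc1Cl` is not yet measured. It differs from compound 3 in one place: cyano in place of chloro on an aromatic carbon.

Going by the values given here, no measured step tests this exchange by itself. Among the compounds with values here, the one step that changes the aryl group, from compound 2 to compound 3, stayed within the scatter, and compound 1, which carries the cyano-bearing aryl group on another side chain, gives a number only modestly higher than compound 3. A step in this assay of a 1.6-fold higher number from compound 3 to compound 4 (0.21 log units; within the scatter) is therefore expected, not beyond the scatter. Compound 4 is estimated at 0.8 nM, with a range from 0.35 nM to 1.8 nM.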

Compound 4, half-maximal inhibitory concentration: 2.2 nM
The estimate for compound 4 lay 2.8-fold (0.44 log units) below the measured number; measured number outside the range, above it.
By their numbers in this assay, from the lowest: compounds 3, 2, 1 and 4 (each within the scatter of the next, the first and the last beyond it).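

In this assay, cyano in place of chloro on the aromatic carbon para to a large group is a single-group exchange with a step beyond the scatter, a 4.5-fold higher number from compound 3 to compound 4 (0.65 log units; beyond the scatter), so affinity responds to the group at this position. The wider exchange to 2-chloro-4-cyanophenyl from 4-methoxy-2-methylphenyl is also beyond the scatter, a 2.4-fold higher number from compound 2 to compound 4 (0.38 log units; beyond the scatter), whereas butyl(ethyl)amino in place of dipropylamino, a 1.8-fold higher number from compound 1 to compound 4 (0.26 log units; within the scatter), is within it, so the two side chains are not told apart with this aryl group. Nothing available accounts for the size of the step from chloro to cyano.

Open, going by these compounds, is how a bromo or trifluoromethyl group would read at this aromatic carbon. Also open, on these data alone, is whether the step from chloro to cyano keeps its size with dipropylamino as the side chain.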